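Swapping the Phenyl on the Phosphate for Quinolinyl

A few compounds are considered here, and "the series" means these few. Any claim that something is new, unique, unknown or untested is made for them only; others in the source may bear on it.

Compound 1 `O=C(O[C@H]1C[C@H](n2cc(F)c(=O)[nH]c2=O)O[C@@H]1COP(=O)(O)Oc1ccccc1)c1ccccc1` gives 6880 nM in a functional assay on T47D cells (Homo sapiens) for cytotoxicity, read by MTT assay, with a stated time of 48 h (a higher number here means a weaker inhibitor, a lower number a stronger inhibitor), the lowest of the two numbers measured. Compound 2 `CCCCCCCCCc1ccc(OP(=O)(O)OC[C@H]2O[C@@H](n3cc(F)c(=O)[nH]c3=O)C[C@@H]2OC(=O)c2ccccc2)cc1` gives 26700 nM. Compound 3 `O=C(O[C@H]1C[C@H](n2cc(F)c(=O)[nH]c2=O)O[C@@H]1COP(=O)(O)Oc1ccc2ncccc2c1)c1ccccc1` carries quinolin-6-yl in place of phenyl on an oxygen. Within the data shown here, the only measured step, a 3.9-fold higher number from compound 1 to compound 2 (0.59 log units; beyond the scatter), is a different change on the same ring, showing that enlarging this ring weakened inhibition. The new ring is also larger, so a modest rise in the number is expected for compound 3, about a 1.6-fold higher number from compound 1 to compound 3 (0.20 log units; within the scatter). Compound 3 is estimated at 11000 nM, within 4500 nM to 27000 nM.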

Compound 3, half-maximal inhibitory concentration: 7140 nM
Compound 3: the middle estimate sits 1.5-fold (0.19 log units) above what was measured; the measured number falls inside the stated range.
By their numbers in this assay, from the lowest: compounds 1 and 3 (each within the scatter of the next); then compound 2.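

In this assay the step of a 1.0-fold higher number from compound 1 to compound 3 (0.02 log units; within the scatter) stays within the scatter, so compound 1 and compound 3 cannot be told apart. On this oxygen, whose other neighbour is phosphorus, quinolin-6-yl with its extra ring and ring nitrogen therefore reads the same as phenyl, a result the nonyl step alone could not have shown. No measurement shown gives a reason for this result.

Still open, going by these compounds, is whether a carboxylic acid or an amine on the phenyl ring of compound 1 would move the number beyond the scatter.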